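A few compounds are considered here, and "the series" means these few. Any claim that something is new, unique, unknown or untested is made for them only; others in the source may bear on it.

Compound 1, `C(#Cc1nc2c(s1)CN(C1CCCCC1)CC2)c1ccccc1`, gives in an assay on HEK293 cells for negative allosteric modulation of metabotropic glutamate receptor 5 (Homo sapiens), read by FLIPR, with a stated time of 1 h (on this read-out lower numbers stand for stronger inhibition and higher numbers for weaker inhibition), only a limit, > 10000 nM.
Compound 2, `CCC(=O)N1CCc2nc(C#Cc3ccccc3)sc2C1`, gives in this assay a value of 38 nM.
Compound 3, `O=C(C1CCC1)N1CCc2nc(C#Cc3ccccc3)sc2C1`, gives in this assay a value of 370 nM.

Among the measured compounds shown here, compound 3 stands highest of the two numbers measured so far. Its nearest neighbour is compound 2, with a 9.7-fold higher number from compound 2 to compound 3 (0.99 log units; beyond the scatter), so growing the acyl group from ethyl to cyclobutyl weakened inhibition by a modest but clear step. Both acyl compounds sit far from the limit of compound 1, as an at least 260-fold lower number from compound 1 to compound 2 (2.42 log units; beyond the scatter) and an at least 27-fold lower number from compound 1 to compound 3 (1.43 log units; beyond the scatter) show; the limit itself is the limit of > 10000 nM in this assay, at which 1 of the 3 values shown sits.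

Compound 4 is `O=C(C1CCC(F)(F)CC1)N1CCc2nc(C#Cc3ccccc3)sc2C1`. The change from compound 3 is 4,4-difluorocyclohexyl in place of cyclobutyl on a carbonyl carbon. For the measured compounds named here, the one measured step that bears on it is a 9.7-fold higher number from compound 2 to compound 3 (0.99 log units; beyond the scatter), a modest loss on enlarging the group on the carbonyl carbon. Compound 4 enlarges that group further, now to a six-membered ring carrying two fluorines, for which no comparison exists among the measured compounds. A further rise of the number, of a size similar to that earlier step, is therefore the expectation, and compound 4 is expected to show a 4.1-fold higher number from compound 3 to compound 4 (0.61 log units; beyond the scatter). This expectation carries wide uncertainty. For compound 4 the estimate in this assay is 1500 nM, with a range from 300 nM to 8000 nM.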

Compound 4, half-maximal inhibitory concentration: > 10000 nM
Compound 4 ended at the assay's limit; the forecaster's own chance of this, stated with the estimate: 15%; middle value at least 6.6-fold (0.82 log units) away from the limit.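

Among the compounds shown here, the carbonyl carbon proves far less tolerant of a larger group than the earlier compounds could show. In this assay, 4,4-difluorocyclohexyl in place of cyclobutyl gives an at least 27-fold higher number from compound 3 to compound 4 (1.43 log units; beyond the scatter), and the same group in place of ethyl gives an at least 260-fold higher number from compound 2 to compound 4 (2.42 log units; beyond the scatter), so the loss on enlarging this group does not stay modest. For compound 4 the value, > 10000 nM, is a limit of the assay and not a number. The amide-type nitrogen in a ring therefore does not by itself secure measurable inhibition, and compound 4 now shares with compound 1 the end of the range: the limit of > 10000 nM in this assay, at which 2 of the 4 values shown sit.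

The compounds shown do not separate the effect of the larger ring from that of the two fluorines, as cyclobutyl and 4,4-difluorocyclohexyl differ in both, and a plain cyclohexyl on the carbonyl carbon would be needed to tell them apart. As far as these compounds go, how far the group can shrink or lengthen also stays open, as neither a methyl nor a straight butyl chain on the carbonyl carbon appears among them.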